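The source may hold more compounds than are shown below. What is called first, only, known or untested is meant among the compounds shown, and "the series" means these compounds.

Compound 1 `COc1cc2nc(SCC(=O)Nc3cccc(Cl)c3)nc(Nc3c(Cl)cc(/C=C/C#N)cc3Cl)c2cc1OC` and compound 3 `COc1cc2nc([S+]([O-])CC(=O)Nc3cccc(Cl)c3)nc(Nc3c(Cl)cc(/C=C/C#N)cc3Cl)c2cc1OC` share most of their structure; the difference between the two cores is not broken down here. In an ADME assay on MT4 cells (Homo sapiens) for cytotoxicity, read by MTT assay, with a stated time of 5 days (on this read-out lower numbers stand for higher toxicity in this test and higher numbers for lower toxicity in this test), compound 1 reaches only the limit of the test, > 208000 nM, which is not a number. Compound 2 `COc1cc2nc(SCC(=O)Nc3ccc(Cl)cc3)nc(Nc3c(Cl)cc(/C=C/C#N)cc3Cl)c2cc1OC` differs from compound 1 by 4-chlorophenyl in place of 3-chlorophenyl on an amide-type nitrogen. In this assay compound 2 gives 29500 nM, so that an at least 7.0-fold lower number from compound 1 to compound 2 (0.84 log units; beyond the scatter); the size of that step rests on (the limit of > 208000 nM in this assay, at which 1 of the 3 values shown sits). Among the measured compounds shown here, compound 3 gives 68900 nM in this assay, the higher of the two numbers measured so far. Compound 4 `COc1cc2nc([S+]([O-])CC(=O)Nc3ccc(Cl)cc3)nc(Nc3c(Cl)cc(/C=C/C#N)cc3Cl)c2cc1OC` has not been measured; it differs from compound 3 by 4-chlorophenyl in place of 3-chlorophenyl on an amide-type nitrogen, the same change at the same place as that from compound 1 to compound 2. Compound 4 is expected to show a 4.6-fold lower number from compound 3 to compound 4 (0.66 log units; beyond the scatter), a step in the same direction as the earlier one, held a little smaller because an at least 7.0-fold lower number from compound 1 to compound 2 (0.84 log units; beyond the scatter) starts from a limit rather than a number. Compound 4 is therefore estimated at 15000 nM in this assay, with a likely range from 5000 nM to 45000 nM.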

Compound 4, half-maximal cytotoxic concentration: 14400 nM
Compound 4: middle estimate off by 1.0-fold (0.02 log units), on the high side, within the range that was stated.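

In this assay, 4-chlorophenyl in place of 3-chlorophenyl on an amide-type nitrogen gives a 4.8-fold lower number from compound 3 to compound 4 (0.68 log units; beyond the scatter), and a lower number here stands for higher toxicity in this test. The change therefore lowers the number on both cores shown, so its direction carries over from one core to the other in these two pairs, and setting the steps side by side gives: the same change on two cores in this assay, an at least 7.0-fold lower number (0.84 log units; beyond the scatter) from compound 1 to compound 2 and a 4.8-fold lower number (0.68 log units; beyond the scatter) from compound 3 to compound 4; the limit leaves it open whether they differ Compound 1 sits at a limit, not a number, so these pairs do not show whether the size of the step also carries over: the limit of > 208000 nM in this assay, at which 1 of the 4 values shown sits.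

The compounds shown have only these two chlorophenyl groups on that nitrogen, which leaves open what a plain phenyl or a fluorophenyl would give there. Also open, as far as these compounds go, is whether the same step would appear on a third core, for example one with an amine in place of the sulfur link.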